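From isopropoxycarbonyl to ethoxycarbonyl

The compounds below may be only part of what the source reports. "The series", "measured", "known", "first", "only" and "open" are said of these compounds alone.

Measured so far in an ADME assay on L6 cells (Rattus norvegicus) for cytotoxicity, read by resazurin assay, with a stated time of 72 h; a lower number here means a stronger inhibitor, a higher number a weaker inhibitor
compound 1 `CC(C)OC(=O)c1ccc(C2=CN3CCC2CC3)cc1` gives 152000 nM
compound 2 `C(=C1\CN2CCC1CC2)\c1ccc(-c2ccccc2)cc1` gives 13400 nM

Compound 1 holds the higher of these two numbers, and compound 2 lies lower by a margin beyond the usual scatter. Compound 3 `CCOC(=O)c1ccc(C2=CN3CCC2CC3)cc1` keeps the core of compound 1 and differs in one place hydrogen in place of methyl on a saturated chain carbon bound to an oxygen next to a carbonyl group and a saturated chain carbon with hydrogen in place of methyl on a saturated chain carbon bound to an oxygen next to a carbonyl group and a saturated chain carbon. Isopropoxycarbonyl thus becomes ethoxycarbonyl. Among the measured compounds shown here, no measured pair shows this change, so the expectation rests on compound 1 alone, at 152000 nM as its anchor. No step beyond the scatter is expected in this assay for this change. The expected step is a 1.1-fold higher number from compound 1 to compound 3 (0.05 log units; within the scatter) and has no firm direction. Compound 3 is estimated at 170000 nM (range 80000 nM to 350000 nM).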

Compound 3, half-maximal inhibitory concentration: 265000 nM
Compound 3: middle estimate off by 1.6-fold (0.19 log units), on the low side; low and high end bracket the measured number.
By their numbers in this assay, from the lowest: compound 2; then compounds 1 and 3 (each within the scatter of the next).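

In this assay the exchange of isopropoxycarbonyl for ethoxycarbonyl gives a 1.7-fold higher number from compound 1 to compound 3 (0.24 log units; within the scatter) and so provides the first one-place comparison among these compounds. At this position, hydrogen in place of methyl leaves compound 1 and compound 3 within the scatter of each other, so this read-out does not separate the two groups. No measurement offered here accounts for the result.

The compounds shown leave open whether a shorter methoxycarbonyl group, a carboxylic acid or an amide in the same place would also stay within the scatter of compound 1. Compound 2 differs from compound 1 and compound 3 in more than one place, so its number cannot be tied to any single group.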